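The source may report more compounds than this note shows. Statements on the series, on what has been measured and on what is new or still open speak of the compounds shown alone.

Of the compounds shown here, two built on the same five-ring core have been tested in a functional assay on the whole organism (strain Wister albino) for inhibition, with Rattus norvegicus as the target, read by paw edema, with stated times of 1 h and 3 h, at a dose of 50 mg/kg by the intraperitoneal route; a higher number here means more inhibition at the dose given (going by the name of the read-out), a lower number less inhibition. Compound 1 `CN1C[C@@H](c2ccc(F)cc2)[C@@]2(Cc3ccccc3C2=O)[C@@]12C(=O)Nc1ccccc12` gives 21.1% in this assay. Compound 2 `CN1C(=O)[C@@]2(c3ccccc31)N(C)C[C@@H](c1ccc(F)cc1)[C@@]21Cc2ccccc2C1=O` carries a methyl in place of hydrogen on an amide-type nitrogen in a ring, and compound 2 gives 26.9%. Against compound 1, compound 2 stands apart only by a number 5.8 percentage points higher from compound 1 to compound 2 (within the scatter), so the two numbers cannot be told apart. Compound 3 `CN1C(=O)[C@@]2(c3ccccc31)N(C)C[C@@H](c1cccs1)[C@@]21Cc2ccccc2C1=O` has not yet been measured. It differs from compound 2 by thiophen-2-yl in place of 4-fluorophenyl on a saturated ring carbon. Among the measured compounds shown here, no measured step concerns a swap of the aromatic group on that saturated ring carbon; the only measured step, a number 5.8 percentage points higher from compound 1 to compound 2 (within the scatter), concerns a different site and lies within the scatter, so it gives no direction for this change. Compound 3 is therefore expected to give 25%, within a wide range from 8% to 45%. This estimate means an expected step of a number 1.9 percentage points lower from compound 2 to compound 3 (within the scatter), none beyond the scatter.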

Compound 3, a percentage reported as inhibition, in the whole organism at one dose (the size of the read-out at that dose, not a potency): 9.1%
Compound 3: middle estimate off by 15.9 percentage points, on the high side; the range from low to high includes it.
By their numbers in this assay, from the lowest: compound 3; then compounds 1 and 2 (each within the scatter of the next).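

In this assay, putting thiophen-2-yl in place of 4-fluorophenyl on the saturated ring carbon gives a number 17.8 percentage points lower from compound 2 to compound 3 (beyond the scatter), the only step among these compounds that lies beyond the scatter. This shows that the aromatic group at this position can change the read-out, something the earlier step at the amide-type nitrogen, a number 5.8 percentage points higher from compound 1 to compound 2 (within the scatter), could not show. Nothing measured here explains the lower number.

On these data alone, with only these two aromatic groups compared at this carbon, it remains open whether the change follows from the sulfur-containing five-membered ring or from losing the fluorine, a question that plain phenyl could help to separate. Also open, as far as these compounds go, is whether furan-2-yl or 4-chlorophenyl would give a number closer to that of compound 2 or compound 3.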